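Notes on the shared core: dropping the hydroxymethyl

A few compounds are considered here, and "the series" means these few. Any claim that something is new, unique, unknown or untested is made for them only; others in the source may bear on it.

The series shares one core carrying a thioether chain and a second substituent on the aromatic carbon. Compound 1 `C#CCSc1cnc2ccccc2c1[Se]CC#CCCl` gives 1.8 ug/mL in a functional assay on CCRF-CEM cells (Homo sapiens) for antiproliferative activity, with a stated time of 72 h; a higher number here means a weaker inhibitor, a lower number a stronger inhibitor. Compound 2 `OCC#CCSc1cnc2ccccc2c1SCC#CCCl` gives 3.3 ug/mL in this assay. Compound 3 `OCC#CCSc1cnc2ccccc2c1Cl` gives 4.1 ug/mL in this assay. Compound 2 thus stands second highest of the three numbers, with compound 3 nearest and compound 1 furthest, both within the scatter.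

Compound 4 `C#CCSc1cnc2ccccc2c1SCC#CCCl` differs from compound 2 by hydrogen in place of hydroxymethyl on a triple-bonded carbon. For the measured compounds named here, the one measured step, a 1.2-fold higher number from compound 2 to compound 3 (0.09 log units; within the scatter), concerns a different site and does not bear directly on this change. Compound 1 also carries propargyl rather than 4-hydroxybut-2-yn-1-yl, but it differs from compound 2 at a second site as well, so the value of compound 1, 1.8 ug/mL, only shows that compound 1 and compound 2 lie within the scatter of each other.

No step beyond the scatter is therefore expected; compound 4 is estimated at 2.6 ug/mL in this assay, with a range from 1.2 ug/mL to 5.5 ug/mL. The expected step is a 1.3-fold lower number from compound 2 to compound 4 (0.10 log units; within the scatter).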

Compound 4, concentration for 50% inhibition: 2.9 ug/mL
For compound 4 the middle estimate is 1.1-fold (0.05 log units) below the measured one; the measured number falls inside the stated range.
By their numbers in this assay, from the lowest: compounds 1, 4, 2 and 3 (each within the scatter of the next, the first and the last beyond it).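

In this assay the exchange of hydroxymethyl for hydrogen on the triple-bonded carbon can now be read directly (a 1.1-fold lower number from compound 2 to compound 4 (0.06 log units; within the scatter)), so 4-hydroxybut-2-yn-1-yl and propargyl are not told apart on the shared core while the second substituent stays fixed. Compound 4 also isolates the exchange of selenium for sulfur in that second substituent (a 1.6-fold higher number from compound 1 to compound 4 (0.21 log units; within the scatter)), and this pair is likewise not told apart. Nothing at hand bears on the cause of either step.

Still open, on these data alone, is whether an amine, a carboxylic acid or a longer chain in place of the hydroxymethyl would leave the number within the scatter. The compounds shown also leave open whether the hydroxymethyl-to-hydrogen exchange reads the same with chlorine on the aromatic carbon, as in compound 3.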